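A few compounds are considered here, and "the series" means these few. Any claim that something is new, unique, unknown or untested is made for them only; others in the source may bear on it.

Among the measured compounds shown here, only two compounds with the same core have numbers so far in a functional assay on FM3A cells (Mus musculus) for antiproliferative activity, with a stated time of 48 h; on this read-out higher numbers stand for weaker inhibition and lower numbers for stronger inhibition. Compound 1 `C=C(Br)C(=O)Nc1ccc(/C=C/C(=O)c2ccc(F)cc2)cc1` gives 1200 nM, and compound 2 `C=C(Br)C(=O)Nc1ccc(/C=C/C(=O)c2ccc(C)cc2)cc1` gives 2100 nM. For the measured compounds named here, compound 2 therefore stands within the usual scatter of compound 1, the only other compound measured, so the two values cannot be told apart. The next compound to be tested is compound 3 `C=C(Br)C(=O)Nc1ccc(/C=C/C(=O)c2ccc(OC)cc2)cc1`, which has methoxy in place of methyl on an aromatic carbon. Going by the values given here, the one measured step that bears on this change also swaps a group on an aromatic carbon, methyl in place of fluoro, and it amounts to a 1.8-fold higher number from compound 1 to compound 2 (0.24 log units; within the scatter). A single step within the scatter is a thin basis and points in no reliable direction. No change beyond the scatter is therefore expected in this assay for compound 3. The estimated step is a 1.2-fold lower number from compound 2 to compound 3 (0.07 log units; within the scatter). Compound 3 is expected to give about 1800 nM, with an estimated range from 700 nM to 4500 nM.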

Compound 3, half-maximal inhibitory concentration: 1200 nM
Beside the measured number, compound 3's estimate is 1.5-fold (0.18 log units) above it; low and high end bracket the measured number.
By their numbers in this assay, from the lowest: compounds 1, 3 and 2 (each within the scatter of the next).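

With methoxy on this aromatic carbon, para to a large group, this assay shows a 1.8-fold lower number from compound 2 to compound 3 (0.24 log units; within the scatter) and no change at the digits printed from compound 1 to compound 3 (within the scatter). Compounds 1, 2 and 3 are now all within the scatter of one another, so fluoro, methyl and methoxy cannot be told apart at this position, even though methoxy brings one more heavy atom and a hydrogen-bond acceptor that methyl does not have. This extends the earlier single comparison to three groups, but no measurement shown here offers an explanation for the similar values.

On these data alone, all three groups are small and uncharged, so it remains open whether an amine, a carboxylic acid or a longer chain such as butoxy at this position would shift the number beyond the scatter. The compounds shown also differ only at this one place, so they say nothing about how changes elsewhere in the shared core would affect the read-out.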